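Benzyl in place of phenylpropyl on a triazole hydroxamate

The source may report more compounds than this note shows. Statements on the series, on what has been measured and on what is new or still open speak of the compounds shown alone.

Compound 1, `O=C(/C=C/c1cn([C@@H]2C[C@@H](C(=O)O)N(Cc3ccccc3)C2)nn1)NO`, carries an acrylic hydroxamate on the triazole and a benzyl group on the ring nitrogen. In an assay on Sf9 cells for inhibition of histone deacetylase 11 (Homo sapiens), read by fluorescence, tested at 0.5 uM (a lower number here means less inhibition, a higher number more inhibition at the concentration tested (going by the name of the read-out)), compound 1 gives 12%. Compound 2, `O=C(NO)c1cccc(-c2cn([C@@H]3C[C@@H](C(=O)O)N(CCCc4ccccc4)C3)nn2)c1`, has a benzohydroxamate on the triazole and a 3-phenylpropyl group on the ring nitrogen. In this assay compound 2 reaches only a limit, < 10%, so no number stands for it. That limit is where compound 2 stands: the limit of < 10% in this assay, at which 1 of the 2 values shown sits.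

Compound 3, `O=C(NO)c1cccc(-c2cn([C@@H]3C[C@@H](C(=O)O)N(Cc4ccccc4)C3)nn2)c1`, keeps the benzohydroxamate of compound 2 but shortens the chain on the ring nitrogen. The change is phenyl in place of phenethyl on a saturated chain carbon bound to an amine nitrogen in a ring, which cut one bond further out reads 3-phenylpropyl to benzyl. Within the data shown here, no measured pair shows what such a change does here, and the only other compound with a benzyl group, compound 1, differs in the hydroxamate as well.

Compound 3 is therefore expected to stay near compound 2, with a step that the limit leaves unreadable from compound 2 to compound 3 that is not beyond the scatter. The value estimated for compound 3 in this assay is 9%, between 0% and 22%.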

Compound 3, a percentage reported as inhibition, at one concentration (the size of the read-out at that concentration, not a potency): < 10%
Compound 3: only a limit was reported; the forecaster's own chance of this, stated with the estimate: 55%; the middle value does not contradict the limit.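

Compound 3 also reaches only a limit in this assay, < 10%, so no number stands for it. Compound 2 likewise sits at a limit, so the step from 3-phenylpropyl to benzyl on the saturated chain carbon bound to the ring amine nitrogen cannot be read, and this position shows neither a gain nor a loss. With benzyl held fixed, 3-(hydroxycarbamoyl)phenyl in place of 2-(hydroxycarbamoyl)ethenyl on an aromatic carbon gives the first readable pair, a number at least 2 percentage points lower from compound 1 to compound 3 (that floor lies within the scatter), so this change is not shown to matter, and limits now account for most of the series: the limit of < 10% in this assay, at which 2 of the 3 values shown sit.

Going by these compounds, it remains open whether any group on the ring nitrogen can lift the inhibition clear of that limit, for instance an amine at the end of the chain or a chain longer than 3-phenylpropyl. The reading at a single concentration also leaves open how the potencies of the benzyl compounds compare, since it gives the size of the read-out and not a potency.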